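Swapping the benzylamide aryl group in a naphthyl acrylonitrile

The source may report more compounds than this note shows. Statements on the series, on what has been measured and on what is new or still open speak of the compounds shown alone.

Measured compounds:
compound 1, `COc1ccc(CNC(=O)/C(C#N)=C/c2ccc(C)o2)cc1`, 60000 nM
compound 2, `COc1ccc(CNC(=O)/C(C#N)=C/c2ccc3ccccc3c2)cc1`, 40000 nM

Both compounds were tested in a functional assay on A2780 cells (Homo sapiens) for inhibition, read by MTT assay, with a stated time of 72 h; on this read-out higher numbers stand for weaker inhibition of growth and lower numbers for stronger inhibition of growth. Compound 1 gives 60000 nM and compound 2 gives 40000 nM. Compound 2 shows the lower of the two numbers, but its gap to compound 1 lies within the usual scatter of repeated measurements, so the two cannot be told apart; both inhibit growth only weakly.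

Compound 3, `N#C/C(=C\c1ccc2ccccc2c1)C(=O)NCc1ccc(Cl)c(Cl)c1`, keeps the core of compound 2 and differs in one place: 3,4-dichlorophenyl in place of 4-methoxyphenyl on a saturated chain carbon bound to an amide-type nitrogen. Among the measured compounds shown here, no measured pair shows what this exchange does, so the size and direction of the step cannot be read from the data. A modest step, if any, is expected, staying close to the scatter. In this assay compound 3 is estimated at 25000 nM, with a range from 8000 nM to 80000 nM. This estimate means a step of a 1.6-fold lower number from compound 2 to compound 3 (0.20 log units; within the scatter).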

Compound 3, concentration for 50% growth inhibition: 44000 nM
Estimate against measurement, compound 3: 1.8-fold (0.25 log units) below; measured number inside the range.
By their numbers in this assay, from the lowest: compounds 2, 3 and 1 (each within the scatter of the next).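

In this assay, placing 3,4-dichlorophenyl in place of 4-methoxyphenyl on a saturated chain carbon bound to an amide-type nitrogen gives a 1.1-fold higher number from compound 2 to compound 3 (0.04 log units; within the scatter), so this exchange produces no change that the assay can detect. In this one pair, a group with one hydrogen-bond acceptor gives way to a group of the same heavy-atom count with none, and growth inhibition stays weak. Nothing available here offers an explanation for this result.

Going by these compounds, it remains open whether an amine or a carboxylic acid on this phenyl ring, or a longer chain at this place, would move the number beyond the scatter. On these data alone, it is also open whether 3,4-dichlorophenyl would behave the same way on the core of compound 1.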